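The source may report more compounds than this note shows. Statements on the series, on what has been measured and on what is new or still open speak of the compounds shown alone.

Compound 1 `CC1CCN(C(=O)c2cccc(N/C(=N/O)c3ccc4occc4c3)c2)CC1` — in an assay on isolated protein for inhibition of Indoleamine 2,3-dioxygenase 1 (Homo sapiens), read by spectrophotometry (on this read-out lower numbers stand for stronger inhibition and higher numbers for weaker inhibition), compound 1 gives > 30000 nM, a limit of the assay rather than a number.
Compound 2 `O/N=C(/NCc1ccccc1)c1ccc2occc2c1` — in this assay compound 2 gives > 30000 nM, again a limit and not a number.

Compound 2 thus stands at the limit of > 30000 nM in this assay, at which 2 of the 2 values shown sit. Compound 3 `O/N=C(/NCc1cccc(Cl)c1)c1ccc2occc2c1` differs from compound 2 by chloro in place of hydrogen on an aromatic carbon. For the measured compounds named here, no step between measured compounds is available, so the data set no size for this change; because compound 2 gives > 30000 nM, the step from compound 2 to compound 3 is expected to be a step that the limit leaves unreadable from compound 2 to compound 3, none beyond the scatter. Compound 3 is estimated at 40000 nM, in the range 15000 nM to 120000 nM, most likely reported once more as a limit.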

Compound 3, half-maximal inhibitory concentration: > 30000 nM
Compound 3 gave a limit, no number; the forecaster's own chance of this, stated with the estimate: 75%; the middle value does not contradict the limit.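

No step can be read from compound 2 to compound 3: both results are limits of the assay, not numbers. The compounds shown leave open what chloro in place of hydrogen on the aromatic carbon does to inhibition.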